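Shifting the Hydroxyl: From Compound 2 to Compound 3

The source may hold more compounds than are shown below. What is called first, only, known or untested is meant among the compounds shown, and "the series" means these compounds.

Compound 1, `Oc1cccc(-c2cc(-c3ccccc3F)cc(-c3ccccc3O)n2)c1`: 24200 nM
Compound 2, `Oc1cccc(-c2cc(-c3ccccc3C(F)(F)F)cc(-c3ccccc3O)n2)c1`: 5680 nM

In a functional assay on T47D cells (Homo sapiens) for inhibition (a lower number here means a stronger inhibitor, a higher number a weaker inhibitor), compound 2 stands lowest of the two numbers measured. Going by the values given here, the only measured step, a 4.3-fold lower number from compound 1 to compound 2 (0.63 log units; beyond the scatter), concerns the trifluoromethyl group and leaves the hydroxyphenyl groups untouched. Compound 3, `Oc1ccc(-c2cc(-c3ccccc3C(F)(F)F)cc(-c3cccc(O)c3)n2)cc1`, differs from compound 2 by 4-hydroxyphenyl in place of 2-hydroxyphenyl on an aromatic carbon. Among the compounds with values here, no measured step bears on this change, so the data give no direction for it; compound 3 is therefore expected to stay close to compound 2, with a step of a 1.0-fold lower number from compound 2 to compound 3 (0.01 log units; within the scatter) that may well lie within the scatter. Compound 3 is estimated at 5500 nM, between 1500 nM and 20000 nM.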

Compound 3, half-maximal inhibitory concentration: 3210 nM
Estimate against measurement, compound 3: 1.7-fold (0.23 log units) above; the measured number falls inside the stated range.
By their numbers in this assay, from the lowest: compounds 3 and 2 (each within the scatter of the next); then compound 1.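

At this place, next to the ring nitrogen, 4-hydroxyphenyl in place of 2-hydroxyphenyl gives in this assay a 1.8-fold lower number from compound 2 to compound 3 (0.25 log units; within the scatter). Going by these compounds alone, this is the first look at the hydroxyphenyl groups, and these two arrangements of the hydroxyl cannot be told apart here. Nothing measured accounts for this result.

From the compounds shown here alone, it remains open whether the hydroxyl matters at all here, which a phenyl ring carrying an amine or a carboxylic acid instead could test. Also open, going by these compounds, is whether this swap would read the same with fluoro in place of trifluoromethyl.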